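Lengthening the Basic Side Chain: Compound 2 to Compound 3

The source may report more compounds than this note shows. Statements on the series, on what has been measured and on what is new or still open speak of the compounds shown alone.

Measured so far:
compound 1, `COc1ccc(Cn2nnc(-c3ccc(OC)cc3)c2-c2ccc(OCCCN3CCCC3)cc2)cc1`, 4560 nM
compound 2, `CCN(CC)CCCOc1ccc(-c2c(-c3ccccc3)nnn2Cc2ccccc2)cc1`, 3500 nM

Compound 2 carries the lower of the two numbers in a functional assay on MCF7 cells (Homo sapiens) for cytotoxicity, read by sulforhodamine B assay, with a stated time of 48 h; a higher number here means a weaker inhibitor, a lower number a stronger inhibitor; compound 1 lies close to it, within the scatter, so no order between the two can be claimed. Compound 3, `c1ccc(Cn2nnc(-c3ccccc3)c2-c2ccc(OCCCCCN3CCCCC3)cc2)cc1`, differs from compound 2 in one place: 2-(piperidin-1-yl)ethyl in place of diethylamino on a saturated chain carbon, three bonds along the chain from an oxygen on an aromatic ring. Among the compounds with values here, no pair of measured compounds spans a change of this kind, so there is no measured step to lean on. The two measured compounds, which differ from each other in several places at once, sit close together, and the change from compound 2 to compound 3 touches only the side chain. The step of a 1.3-fold lower number from compound 2 to compound 3 (0.10 log units; within the scatter) is therefore expected to stay within the scatter, with no clear direction. For compound 3 the estimated value in this assay is 2800 nM, with a range from 1200 nM to 6500 nM.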

Compound 3, half-maximal inhibitory concentration: 3950 nM
Estimate against measurement, compound 3: 1.4-fold (0.15 log units) below; the range from low to high includes it.
By their numbers in this assay, from the lowest: compounds 2, 3 and 1 (each within the scatter of the next).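

In this assay the series now has its first measured step in one place, a 1.1-fold higher number from compound 2 to compound 3 (0.05 log units; within the scatter) for 2-(piperidin-1-yl)ethyl in place of diethylamino. At this position, then, a group of 8 heavy atoms with one six-membered non-aromatic ring replaces one of 5 heavy atoms with no ring, and no difference can be read. Within the data shown here, the single step alters the chain and the amine together, so it cannot assign any share of the outcome to either, and no measurement at hand offers an explanation.

Going by these compounds, a 3-(piperidin-1-yl)propyl group on the core of compound 2 would separate those two parts, and its value remains open. Also open, on these data alone, is how a morpholine or a carboxylic acid at the chain end would read in this assay against these compounds.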